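Chloro in Place of Hydrogen on Two Related Cores

A few compounds are considered here, and "the series" means these few. Any claim that something is new, unique, unknown or untested is made for them only; others in the source may bear on it.

Three compounds have a value in a physicochemical assay for lipophilicity; a lower number here means a more polar compound, a higher number a more lipophilic compound. Compound 1 `COc1c(OC)c(OC(=O)C(C)(C)C)c2ccccc2c1OC(=O)C(C)(C)C` gives 5.69. Compound 3 `COc1c(OC)c(OC(=O)C(C)(C)C)c2cc(Cl)ccc2c1OC(=O)C(C)(C)C` gives 6.6. Compound 2 `CC(=O)Oc1c(Oc2ccccc2)c(Oc2ccccc2)c(OC(C)=O)c2ccccc12` gives 4.8, the lowest of the three, with compound 1 nearest and compound 3 furthest. Compound 4 `CC(=O)Oc1c(Oc2ccccc2)c(Oc2ccccc2)c(OC(C)=O)c2cc(Cl)ccc12` has not yet been measured.

Compound 3 differs from compound 1 by chloro in place of hydrogen on an aromatic carbon. This change gave a number 0.91 log units higher from compound 1 to compound 3 (beyond the scatter). The difference between the cores of compound 1 and compound 2 is not broken down here. Compound 4 differs from compound 2 by chloro in place of hydrogen on an aromatic carbon, and the place of the change is described in the same words as for the pair already measured, so it is the same change made on the second core.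

Whether the step will be of like size on a core whose remaining groups are so different is not known from these three values. On the strength of a number 0.91 log units higher from compound 1 to compound 3 (beyond the scatter), a step of the same order is nonetheless expected. For compound 4 the expected step is a number 0.80 log units higher from compound 2 to compound 4 (beyond the scatter). Compound 4 is therefore estimated at 5.6, with a range from 5.2 to 6.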

Compound 4, partition coefficient: 5.6
Compound 4: the middle estimate sits on the measured number at the digits printed, and the stated range covers the measured number.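

In this assay, chloro in place of hydrogen on an aromatic carbon gave a number 0.80 log units higher from compound 2 to compound 4 (beyond the scatter), and on the other core the same change gave a number 0.91 log units higher from compound 1 to compound 3 (beyond the scatter), so the step pointed the same way on both cores. Among these compounds, these are only two matched pairs, so they show that the change carried across these two cores, not that it would carry to any other core or to a different aromatic carbon. Nothing measured here explains the step on either core.

The compounds shown leave open whether a bromo, a methyl or a methoxy group at the same place would give a step like that of chloro. They also leave open whether chloro would give a similar step on a core bearing an amine or a carboxylic acid.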